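A few compounds are considered here, and "the series" means these few. Any claim that something is new, unique, unknown or untested is made for them only; others in the source may bear on it.

Measured so far in an ADME assay on S9 fraction from liver (Rattus norvegicus) for metabolic stability, read by LC-MS, using NADPH, with a stated time of 30 min; on this read-out lower numbers stand for a less stable compound and higher numbers for a more stable compound:
- Compound 1, `CCCCCCCCc1ccc(OCC(=O)Cn2ncnn2)cc1`, gives < 5%; this is a limit of the assay.
- Compound 2, `CCCCCCCCc1ccc(OCC(=O)Cn2cnnn2)cc1`, gives 22%.
- Compound 3, `CCCCCCCCc1ccc(OCC(=O)Cn2nnc(SC)n2)cc1`, gives < 5%; this too is a limit of the assay.

Compound 3 thus sits at the limit of < 5% in this assay, at which 2 of the 3 values shown sit, not at a number. Compound 4, `CCCCCCCCc1ccc(OCC(=O)Cn2nnnc2C)cc1`, differs from it by 5-methyl-1H-tetrazol-1-yl in place of 5-(methylsulfanyl)-2H-tetrazol-2-yl on a saturated chain carbon bound to a carbonyl carbon. Of the measured steps, a number at least 17 percentage points higher from compound 1 to compound 2 (beyond the scatter) shows the 1H-tetrazol-1-yl pattern reading higher than the 2H-tetrazol-2-yl pattern, and a number at least 17 percentage points lower from compound 2 to compound 3 (beyond the scatter) shows the reverse move down; a step that the two limits leave unreadable from compound 1 to compound 3 stays unreadable. A rise beyond the scatter is therefore expected, with compound 2 as the nearest reference point. Compound 4 is estimated at 20%, between 5% and 45%, meaning an expected step of a number at least 15 percentage points higher from compound 3 to compound 4 (beyond the scatter).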

Compound 4, percent of the compound remaining: 32%
For compound 4 the middle estimate is 12 percentage points below the measured one; the range from low to high includes it.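

In this assay, 5-methyl-1H-tetrazol-1-yl on a saturated chain carbon bound to a carbonyl carbon gives a number at least 27 percentage points higher from compound 3 to compound 4 (beyond the scatter) and a number at least 27 percentage points higher from compound 1 to compound 4 (beyond the scatter). Both steps start from a limit of the assay: the limit of < 5% in this assay, at which 2 of the 4 values shown sit. Methyl in place of hydrogen on an aromatic carbon gives a number 10 percentage points higher from compound 2 to compound 4 (within the scatter), so this substitution leaves compound 2 and compound 4 unseparated, and the 1H-tetrazol-1-yl compounds stay clear of the limit.

Open, going by these compounds, are the readings of 5-methyl-2H-tetrazol-2-yl and 5-(methylsulfanyl)-1H-tetrazol-1-yl, which would separate substituent from attachment. Also open, on these data alone, is how an ethyl, an amine or a carboxylic acid in place of the methyl would read.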